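The source may report more compounds than this note shows. Statements on the series, on what has been measured and on what is new or still open speak of the compounds shown alone.

Measured in a functional assay on HCT-116 cells (Homo sapiens) for inhibition, read by MTT assay, with a stated time of 72 h; on this read-out higher numbers stand for weaker inhibition of growth and lower numbers for stronger inhibition of growth:

compound 1 `COC1=C(OC)C(=O)C(CCCCCCn2cc(C[C@H](O)COCCOC[C@@H](O)Cc3ccc(-c4ccccc4)cc3)nn2)=C(C)C1=O` gives 5000 nM
compound 2 `O[C@H](COCCOC[C@@H](O)Cc1cn(-c2cccs2)nn1)Cc1ccc(-c2ccccc2)cc1` gives 33400 nM
compound 3 `COC1=C(OC)C(=O)C(CCCCCCCCCCCCCCCn2cc(C[C@H](O)COCCOC[C@@H](O)Cc3ccc(-c4ccccc4)cc3)nn2)=C(C)C1=O` gives 1500 nM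

Of these three, compound 2 stands highest, so it is the weakest inhibitor of growth here; its gaps to compound 1, the nearest, and to compound 3, the furthest, both lie beyond the usual scatter of this assay. Compound 4 `N#Cc1ccc(Cn2cc(C[C@H](O)COCCOC[C@@H](O)Cc3ccc(-c4ccccc4)cc3)nn2)cc1` is not yet measured. It differs from compound 2 in one place: 4-cyanobenzyl in place of thiophen-2-yl on an aromatic nitrogen. Among the compounds with values here, no step of this kind has been measured, so the direction rests on expectation alone. A modest move toward stronger inhibition is expected, the step of a 1.7-fold lower number from compound 2 to compound 4 (0.22 log units; within the scatter) being the estimated change, though a result within the scatter would not surprise. Compound 4 is therefore expected to give about 20000 nM in this assay, with a likely range from 6000 nM to 60000 nM.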

Compound 4, concentration for 50% growth inhibition: 8800 nM
Compound 4: middle estimate off by 2.3-fold (0.36 log units), on the high side; the range from low to high includes it.
By their numbers in this assay, from the lowest: compound 3; then compounds 1 and 4 (each within the scatter of the next); then compound 2.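

In this assay the change to 4-cyanobenzyl in place of thiophen-2-yl on this aromatic nitrogen gives a 3.8-fold lower number from compound 2 to compound 4 (0.58 log units; beyond the scatter) and so shows that the group held here affects inhibition of growth. The swap alters the ring, adds a nitrile and brings in more heavy atoms, so these changes cannot be told apart. No measured evidence on the cause of this step is available. Still open, on these data alone, is whether the nitrile or the benzyl part carries the step, a question that plain benzyl on this nitrogen would help to answer.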